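A few compounds are considered here, and "the series" means these few. Any claim that something is new, unique, unknown or untested is made for them only; others in the source may bear on it.

Working notes on the amide variation. Compound 1 `CCCS(=O)(=O)N1CCC(CNC(=O)C2CC2)(C(=O)N2CCOCC2)CC1` carries a cyclopropyl on the amide carbonyl; in an assay on isolated protein for inhibition of sodium- and chloride-dependent glycine transporter 1 (Homo sapiens) (on this read-out lower numbers stand for stronger inhibition and higher numbers for weaker inhibition), compound 1 gives only a limit, > 5000 nM. Compound 2 `CCCS(=O)(=O)N1CCC(CNC(=O)c2ccc(F)cc2C(F)(F)F)(C(=O)N2CCOCC2)CC1` carries 4-fluoro-2-(trifluoromethyl)phenyl in its place, and in this assay compound 2 gives 67.8 nM. Among the measured compounds shown here, the step of an at least 73-fold lower number from compound 1 to compound 2 (1.86 log units; beyond the scatter) is the one measured change on this carbonyl carbon, and it is large; its lower end rests on the limit (the limit of > 5000 nM in this assay, at which 1 of the 3 values shown sits). Compound 3 `CCCS(=O)(=O)N1CCC(CNC(=O)c2ccc(Cl)cc2Cl)(C(=O)NCC)CC1` differs from compound 2 in two places, and in this assay compound 3 gives 517 nM. Compound 2 therefore stands lowest of the two numbers shown, with compound 3 next.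

Compound 4 `CCCS(=O)(=O)N1CCC(CNC(=O)c2ccccc2OC(F)(F)F)(C(=O)N2CCOCC2)CC1` is not yet measured. Its change from compound 2: 2-(trifluoromethoxy)phenyl in place of 4-fluoro-2-(trifluoromethyl)phenyl on a carbonyl carbon. For the measured compounds named here, no measured step covers this exchange of one substituted aryl for another; the step of an at least 73-fold lower number from compound 1 to compound 2 (1.86 log units; beyond the scatter) only shows that an aromatic amide gives a far lower number than the cyclopropyl one, and compound 3 shows that another substituted aryl amide stays in the same broad region even when the second amide is also altered. Compound 4 keeps an aryl amide, so a number of the same order as compound 2 is expected, most likely a modest rise. For compound 4 in this assay a value of 150 nM is estimated, between 50 nM and 500 nM, corresponding to an expected step of a 2.2-fold higher number from compound 2 to compound 4 (0.34 log units; beyond the scatter).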

Compound 4, half-maximal inhibitory concentration in the sodium- and chloride-dependent glycine transporter 1 assay: 88.4 nM
Compound 4: middle estimate off by 1.7-fold (0.23 log units), on the high side; the measured number falls inside the stated range.
By their numbers in the sodium- and chloride-dependent glycine transporter 1 assay, from the lowest: compounds 2 and 4 (each within the scatter of the next); then compound 3. At a limit, above all of these: compound 1.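

In the sodium- and chloride-dependent glycine transporter 1 assay, a 1.3-fold higher number from compound 2 to compound 4 (0.12 log units; within the scatter), so 2-(trifluoromethoxy)phenyl and 4-fluoro-2-(trifluoromethyl)phenyl cannot be told apart on this carbonyl carbon, although the entering group has 1 hydrogen-bond acceptor and the leaving group has 0. A second substituted aryl group now also gives a large step away from the cyclopropyl amide, so that result no longer rests on one aryl group alone: an at least 56-fold lower number from compound 1 to compound 4 (1.75 log units; beyond the scatter), with the lower end of the step set by a limit: the limit of > 5000 nM in the sodium- and chloride-dependent glycine transporter 1 assay, at which 1 of the 4 values shown sits. In a physicochemical assay for lipophilicity (a lower number here means a more polar compound, a higher number a more lipophilic compound), compound 2 gives only a limit, < 1.4. In the physicochemical assay compound 4 also gives only a limit, < 1.4. In the physicochemical assay, the step for this exchange cannot be read, and nothing can be said about any difference in partition coefficient: the limit of < 1.4 in the physicochemical assay, at which 2 of the 2 values shown sit.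

The compounds shown leave open whether an aromatic ring is needed on this carbonyl carbon, since only cyclopropyl and substituted phenyl groups appear there, and an unsubstituted phenyl, a pyridine or a longer alkyl chain would test this directly. The effect of the second amide also remains unresolved. Compound 3 changes it together with the aryl group, so a matched pair carrying a single change at that amide, such as a carboxylic acid in its place, is still needed.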